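Removing one trifluoromethyl from a urea: what to expect

The compounds below may be only part of what the source reports. "The series", "measured", "known", "first", "only" and "open" are said of these compounds alone.

Measured so far:
compound 1, `COc1cc(Cl)cc(-c2nn(-c3cccc(NC(=O)c4ccc(Cl)c(Cl)c4)c3)cc2-c2ccncc2)c1`, 74.1%
compound 2, `COc1cc(Cl)cc(-c2nn(-c3cccc(NC(=O)Nc4cc(C(F)(F)F)cc(C(F)(F)F)c4)c3)cc2-c2ccncc2)c1`, -26.9%

Both values come from a functional assay on 786-0 cells (Homo sapiens) for inhibition, read by sulforhodamine B assay, with a stated time of 48 h, tested at 10 uM; a higher number here means a weaker effect of the compound at the concentration tested, a lower number a stronger effect. Compound 2 stands at the lowest of the two numbers; its nearest neighbour is compound 1, whose value lies far higher, a gap well beyond the usual scatter of this assay. For the measured compounds named here, no pair of compounds differing in a single place has been measured, so nothing is yet known about how single changes shift the read-out here.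

Compound 3, `COc1cc(Cl)cc(-c2nn(-c3cccc(NC(=O)Nc4cccc(C(F)(F)F)c4)c3)cc2-c2ccncc2)c1`, is the next compound to be measured. It is compound 2 with one change: hydrogen in place of trifluoromethyl on an aromatic carbon.

Going by the values given here, with no single-place step on record, the size of this step is uncertain. The step from compound 2 to compound 3 is expected to be upward, a number 46.9 percentage points higher from compound 2 to compound 3 (beyond the scatter), meaning a weaker effect. Compound 3 is therefore expected to give about 20% in this assay, within a broad range from -20% to 60%.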

Compound 3, a percentage reported as activity, at one concentration (the size of the read-out at that concentration, not a potency): 13.2%
Beside the measured number, compound 3's estimate is 6.8 percentage points above it, and the stated range covers the measured number.
By their numbers in this assay, from the lowest: compound 2; then compound 3; then compound 1.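

In this assay, this position turns out to matter: a number 40.1 percentage points higher from compound 2 to compound 3 (beyond the scatter), so hydrogen in place of trifluoromethyl on this aromatic carbon clearly weakens the effect. Even so, the urea that keeps one trifluoromethyl remains far more effective than the amide, with a number 60.9 percentage points lower from compound 1 to compound 3 (beyond the scatter), although that step replaces a whole group on the carbonyl carbon and cannot be credited to any single part of it. Nothing measured here offers a reason for either step.

Still open, going by these compounds, is whether a chlorine or a nitrile in place of that hydrogen would bring the value back towards that of compound 2. It is also unclear what would happen if the remaining trifluoromethyl were replaced by hydrogen or a methyl group.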